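Swapping a Dihydroxyphenyl for a Dimethylaminophenyl Group

The compounds below may be only part of what the source reports. "The series", "measured", "known", "first", "only" and "open" are said of these compounds alone.

Measured so far in a functional assay on the whole organism (strain Wistar) for inhibition, with Rattus norvegicus as the target, read by paw edema, with a stated time of 3 h, at a dose of 10 mg/kg by the intraperitoneal route; on this read-out lower numbers stand for less inhibition and higher numbers for more inhibition at the one dose given (going by the name of the read-out):
- compound 1, `O=C(N/N=C/c1cccc(Cl)c1)c1cccnc1Nc1cccc(C(F)(F)F)c1`, gives 55.2%
- compound 2, `O=C(N/N=C/c1cccc(O)c1)c1cccnc1Nc1cccc(C(F)(F)F)c1`, gives 49%
- compound 3, `O=C(N/N=C/c1ccc(O)c(O)c1)c1cccnc1Nc1cccc(C(F)(F)F)c1`, gives 38.2%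

All three share one core and differ only in the ring hanging from the carbon that is double-bonded to nitrogen. Compound 3 sits lowest of the three: compound 2 lies nearest to it, with a number 10.8 percentage points lower from compound 2 to compound 3 (beyond the scatter), and compound 1 lies furthest, with a number 17 percentage points lower from compound 1 to compound 3 (beyond the scatter). The change from compound 1 to compound 2 was a number 6.2 percentage points lower from compound 1 to compound 2 (within the scatter).

Compound 4, `CN(C)c1ccc(/C=N/NC(=O)c2cccnc2Nc2cccc(C(F)(F)F)c2)cc1`, has not yet been measured. Its change from compound 3 is 4-(dimethylamino)phenyl in place of 3,4-dihydroxyphenyl on a carbon with a double bond to nitrogen.

For the measured compounds named here, no measured step puts a dimethylamino group onto this ring, so the guide is only indirect. Each added hydroxy group went with a lower number, as the steps from compound 1 to compound 3 show, and compound 4 carries no hydroxy group at all. On that basis a rise back toward the level of compound 1 is expected, though the size is uncertain; the estimated step is a number 11.8 percentage points higher from compound 3 to compound 4 (beyond the scatter). For compound 4 the expected value in this assay is 50%, with a range from 36% to 64%.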

Compound 4, a percentage reported as inhibition, in the whole organism at one dose (the size of the read-out at that dose, not a potency): 39.5%
For compound 4 the middle estimate is 10.5 percentage points above the measured one; measured number inside the range.
By their numbers in this assay, from the lowest: compounds 3, 4, 2 and 1 (each within the scatter of the next, the first and the last beyond it).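

Removing every hydroxy group from this ring does not by itself bring the number back: in this assay, 4-(dimethylamino)phenyl in place of 3,4-dihydroxyphenyl gives a number 1.3 percentage points higher from compound 3 to compound 4 (within the scatter), so the trend among compound 1, compound 2 and compound 3, where each added hydroxy group went with a lower number, does not carry over to a ring of a different kind, and compound 4 goes against it. The other comparisons place the new ring more exactly: a number 9.5 percentage points lower from compound 2 to compound 4 (within the scatter) leaves compound 4 not separable from the 3-hydroxyphenyl ring, whereas a number 15.7 percentage points lower from compound 1 to compound 4 (beyond the scatter) sets it clearly apart from the 3-chlorophenyl ring. So a ring with no hydroxy group can still sit at the level of the hydroxylated rings, and the data offer no measured explanation for that.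

The compounds shown leave open whether the dimethylamino group itself holds the number down, or whether any group other than chloro on this ring would do the same. A methoxy group, a plain amine or a carboxylic acid on this ring could help separate those two readings.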